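Swapping chloro for methyl on the aryl ring of an acylthiourea series

This account rests on a few compounds, and the source may have more. Where it says the series, first, only, none or still open, it means among the compounds named here.

Three measured compounds share one core. Compound 1 `Cc1ccc(NC(=S)NC(=O)c2cn(-c3ccccc3)nc2-c2ccc(Cl)cc2)cc1` gives 5980 nM in a functional assay on MCF7 cells (Homo sapiens) for inhibition, read by CCK-8 assay, with a stated time of 48 h; on this read-out lower numbers stand for stronger inhibition and higher numbers for weaker inhibition. Compound 2 `O=C(NC(=S)Nc1ccc(Cl)cc1)c1cn(-c2ccccc2)nc1-c1ccc(Cl)cc1` gives 5360 nM. Compound 3 `O=C(NC(=S)Nc1ccc(F)cc1)c1cn(-c2ccccc2)nc1-c1ccc(Cl)cc1` gives 5990 nM. The change from compound 2 to compound 3 is fluoro in place of chloro on an aromatic carbon, and the step is a 1.1-fold higher number from compound 2 to compound 3 (0.05 log units; within the scatter). The change from compound 2 to compound 1 is methyl in place of chloro on an aromatic carbon, and it produced a 1.1-fold higher number from compound 2 to compound 1 (0.05 log units; within the scatter). Compound 4 `Cc1ccc(-c2nn(-c3ccccc3)cc2C(=O)NC(=S)Nc2ccc(F)cc2)cc1` is not yet measured; it differs from compound 3 by methyl in place of chloro on an aromatic carbon, the same change as between compound 2 and compound 1. Because a 1.1-fold higher number from compound 2 to compound 1 (0.05 log units; within the scatter) was flat and all three values sit close together, the expected step is a 1.1-fold higher number from compound 3 to compound 4 (0.04 log units; within the scatter). Compound 4 is estimated at 6500 nM, most likely between 3000 nM and 14000 nM.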

Compound 4, half-maximal inhibitory concentration: 6420 nM
Estimate against measurement, compound 4: 1.0-fold (0.01 log units) above; low and high end bracket the measured number.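

In this assay, among the compounds shown here, the swap from 4-chlorophenyl to 4-methylphenyl gives a 1.1-fold higher number from compound 3 to compound 4 (0.03 log units; within the scatter), so the number stays flat here, and the two cores agree: the same change on two cores in this assay, a 1.1-fold higher number (0.05 log units; within the scatter) from compound 2 to compound 1 and a 1.1-fold higher number (0.03 log units; within the scatter) from compound 3 to compound 4, 1.0-fold (0.02 log units) apart, within the scatter of two such steps This shows only that the swap left the number unmoved in these two pairs, where it sits on a different aryl ring in each. Since neither step is beyond the scatter, it does not show that a real effect of the change would carry from one core to another.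

From the compounds shown here alone, whether an amine, a carboxylic acid or a longer chain in place of the chloro would move the number remains open. So does whether the flat result would hold on cores beyond these two.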